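This account rests on a few compounds, and the source may have more. Where it says the series, first, only, none or still open, it means among the compounds named here.

Three analogues sharing one core have been measured in a functional assay, with a stated time of 20 min, tested at 2 uM; a lower number here means a weaker effect, a higher number a stronger effect of the compound at the concentration tested. Compound 1 `COc1cc(/C=C/C(=O)C2=C(/C=C/c3ccc(O)c(OC)c3)NC(=O)NC2c2ccccc2)ccc1O` gives 10.5%. Compound 2 `COc1cc(/C=C/C(=O)C2=C(/C=C/c3ccc(O)c(OC)c3)NC(=O)NC2c2ccc(C)cc2)ccc1O`, which carries methyl in place of hydrogen on an aromatic carbon, gives 15.5%. Compound 3 `COc1cc(/C=C/C(=O)C2=C(/C=C/c3ccc(O)c(OC)c3)NC(=O)NC2c2cccc([N+](=O)[O-])c2)ccc1O`, with nitro in place of hydrogen on an aromatic carbon, gives 10.2%. Compound 3 holds the lowest of the three numbers, yet the step of a number 0.3 percentage points lower from compound 1 to compound 3 (within the scatter) and the step of a number 5.3 percentage points lower from compound 2 to compound 3 (within the scatter) are both within the scatter, so none of the three can be called more or less active than another on these numbers.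

Compound 4 `COc1cc(/C=C/C(=O)C2=C(/C=C/c3ccc(O)c(OC)c3)NC(=O)NC2c2ccccc2Cl)ccc1O` has not yet been measured. It differs from compound 3 by 2-chlorophenyl in place of 3-nitrophenyl on a saturated ring carbon. Going by the values given here, the closest precedent is the exchange of one aryl group for another on that same saturated ring carbon, a number 5.3 percentage points lower from compound 2 to compound 3 (within the scatter), which stayed within the scatter; the smaller edits a number 5 percentage points higher from compound 1 to compound 2 (within the scatter) and a number 0.3 percentage points lower from compound 1 to compound 3 (within the scatter) did likewise. Given the step of a number 5.3 percentage points lower from compound 2 to compound 3 (within the scatter), the expected step of a number 1.3 percentage points higher from compound 3 to compound 4 (within the scatter) is none beyond the scatter. Compound 4 is therefore estimated at 11.5%, with a range from 4% to 20%.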

Compound 4, a percentage reported as activity, at one concentration (the size of the read-out at that concentration, not a potency): 16.6%
Compound 4: the middle estimate sits 5.1 percentage points below what was measured; the range from low to high includes it.
By their numbers in this assay, from the lowest: compounds 3, 1, 2 and 4 (each within the scatter of the next).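

Placing 2-chlorophenyl on the saturated ring carbon brings a halogen, and a substituent at the 2-position of the phenyl ring, into the series, and in this assay the hydrogen-to-chloro exchange gives a number 6.1 percentage points higher from compound 1 to compound 4 (within the scatter). Going by these compounds alone, the exchanges between aryl groups read the same way: replacing 3-nitrophenyl gives a number 6.4 percentage points higher from compound 3 to compound 4 (within the scatter), the largest step so far, and replacing 4-methylphenyl gives a number 1.1 percentage points higher from compound 2 to compound 4 (within the scatter). With chloro, methyl and nitro on the phenyl ring at the 2-, 4- and 3-positions, all four compounds remain within the scatter of their neighbours, so this position has so far tolerated each of these changes without a separable effect on the read-out.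

No measurement here bears on why these small steps arise. On these data alone, it remains open whether a phenyl ring carrying an amine or a carboxylic acid, or a longer alkyl chain in place of the phenyl ring on that saturated ring carbon, would move the number beyond the scatter.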